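The compounds below may be only part of what the source reports. "The series", "measured", "known", "first", "only" and "open" are said of these compounds alone.

Compound 1 `CCOC(=O)c1ccc(Nc2ccnc(SCC(=O)c3ccc([N+](=O)[O-])cc3)n2)cc1`: 58%
Compound 2 `CC(=O)c1cccc(Nc2ccnc(SCC(=O)c3ccc(-c4ccccc4)cc3)n2)c1`: 29%
Compound 3 `CC(=O)c1ccc(Nc2ccnc(SCC(=O)c3ccc(Cl)cc3)n2)cc1`: 33%

All three values come from a functional assay on MOLT-4 cells (Homo sapiens) for inhibition, read by sulforhodamine B assay, with a stated time of 48 h, tested at 10 uM (on this read-out higher numbers stand for more inhibition of growth at the one concentration tested and lower numbers for less inhibition of growth), and the compounds differ from one another in more than one place, so no single structural change can be read from them. Compound 2 gives 29% and compound 3 gives 33% in this read-out. These two lie within the scatter of each other at the low end of the range, while compound 1 stands higher than compound 2 by more than the scatter.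

The unmeasured compound 4 `CC(=O)c1cccc(Nc2ccnc(SCC(=O)c3ccc(C(F)(F)F)cc3)n2)c1` departs from compound 2 in one place, with trifluoromethyl in place of phenyl on an aromatic carbon. Among the compounds with values here, no measured pair isolates this change. Compound 3 also lacks that phenyl and gives 33% while compound 1 also lacks it and gives 58% in the same read-out, which leaves the outcome open with only a slight lean upward. In this assay a small rise is therefore expected, but none beyond the scatter. The estimated change is a number 6 percentage points higher from compound 2 to compound 4 (within the scatter) and it would remain within the usual scatter. For compound 4 the expected value is 35% with an estimated range from 15% to 55% for repeated measurements.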

Compound 4, percent growth inhibition at one concentration: 24%
Compound 4: middle estimate off by 11 percentage points, on the high side; the measured number falls inside the stated range.
By their numbers in this assay, from the lowest: compounds 4, 2 and 3 (each within the scatter of the next); then compound 1.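

In this assay, within the data shown here, putting trifluoromethyl in place of phenyl on an aromatic carbon para to a large group gives a number 5 percentage points lower from compound 2 to compound 4 (within the scatter), the first step in this set that isolates a single change. At this position, the six-membered aromatic ring of carbon only can thus give way to a smaller group with no ring, and the two numbers stay within the scatter of each other, so the phenyl ring shows no distinct contribution to the low level of growth inhibition seen with compound 2. No supporting data bear on this result, and the step stands as an observation without an explanation.

From the compounds shown here alone, whether the higher number of compound 1, at 58%, belongs to its nitro group at this position, to its ethyl ester elsewhere in the molecule, or to both stays open, as compound 1 differs from compound 2 and compound 4 in more than one place. How an amine or a carboxylic acid at this same position would compare with phenyl and trifluoromethyl also remains an open question.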